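The source may report more compounds than this note shows. Statements on the series, on what has been measured and on what is new or still open speak of the compounds shown alone.

In a functional assay on MCF7 cells (Homo sapiens) for inhibition, read by MTT assay, with a stated time of 72 h (a higher number here means a weaker inhibitor, a lower number a stronger inhibitor), compound 1 (`COc1cc(NC(C)CCCNC(=O)Nc2cccc(Cl)c2)c2ncccc2c1`) gives 11000 nM and compound 2 (`COc1cc(NC(C)CCCNC(=O)Nc2cccc(O)c2)c2ncccc2c1`) gives 11000 nM as well, which amounts to no change at the digits printed from compound 1 to compound 2 (within the scatter) when hydroxy replaces chloro. Compound 3 (`COc1cc(NC(C)CCCNC(=O)Nc2ccc(C(F)(F)F)cc2)c2ncccc2c1`) stands lowest of the three at 1900 nM and a 5.8-fold lower number from compound 2 to compound 3 (0.76 log units; beyond the scatter) matches a 5.8-fold lower number from compound 1 to compound 3 (0.76 log units; beyond the scatter) in size. Compound 4 (`COc1cc(NC(C)CCCNC(=O)Nc2ccc(Cl)cc2)c2ncccc2c1`) carries chloro in place of trifluoromethyl on an aromatic carbon, para to a large group (chloro in place of trifluoromethyl on an aromatic carbon). Among the measured compounds shown here, no measured step isolates this swap. Compound 1 also carries chloro, but its step (a 5.8-fold lower number from compound 1 to compound 3 (0.76 log units; beyond the scatter)) changes 3-chlorophenyl to 4-(trifluoromethyl)phenyl, so only part of that size is expected to return. In this assay the expected move, toward a higher number, is a 2.0-fold higher number from compound 3 to compound 4 (0.30 log units; within the scatter) (an estimate). For compound 4 the estimated value is 3800 nM (expected range 1500 nM to 10000 nM).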

Compound 4, half-maximal inhibitory concentration: 12000 nM
Beside the measured number, compound 4's estimate is 3.2-fold (0.50 log units) below it, outside the stated range (above it).
By their numbers in this assay, from the lowest: compound 3; then compounds 1, 2 and 4 (each within the scatter of the next).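

In this assay, among the compounds shown here, exchanging trifluoromethyl for chloro with nothing else changed gives a 6.3-fold higher number from compound 3 to compound 4 (0.80 log units; beyond the scatter) and so isolates this swap for the first time. The other two steps, a 1.1-fold higher number from compound 1 to compound 4 (0.04 log units; within the scatter) and a 1.1-fold higher number from compound 2 to compound 4 (0.04 log units; within the scatter), stay within the scatter, so among these compounds the 4-position alone does not go with the lower number; only compound 3, with trifluoromethyl there, stands apart. No measurement given here explains why the two groups differ.

On these data alone, whether a nitrile or a methoxy group in that place would match trifluoromethyl or chloro stays open.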